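The source may report more compounds than this note shows. Statements on the series, on what has been measured and on what is new or still open speak of the compounds shown alone.

In a functional assay on the whole organism with Mus musculus as the target (on this read-out higher numbers stand for an effect only at larger amounts of compound and lower numbers for an effect already at smaller amounts), compound 1 `Cc1ccc(-c2nc3cccnc3n2CC(N)=O)cc1` gives 50.5 mg/kg, compound 2 `Cc1ccc(-c2nc3cccnc3n2CC(=O)N(C)C)cc1` gives 4.7 mg/kg, and compound 3 `CCCN(CCC)C(=O)Cn1c(-c2ccc(Cl)cc2)nc2cccnc21` gives 11 mg/kg, the second highest of these three numbers. Compound 4 `O=C(Cn1c(-c2ccc(Cl)cc2)nc2cccnc21)Nc1ccccn1` has not yet been measured. It differs from compound 3 by one change, (pyridin-2-yl)amino in place of dipropylamino on a carbonyl carbon. Within the data shown here, only one measured step bears on this change, the swap of amino for dimethylamino on a carbonyl carbon, which gave an 11-fold lower number from compound 1 to compound 2 (1.03 log units; beyond the scatter). That large step went from a group with an amide hydrogen to one without. Compound 4 gains an amide hydrogen that compound 3 lacks, so the step is read here in reverse, pointing towards a higher number. Among the measured compounds shown here, the guide is loose, since (pyridin-2-yl)amino is not amino and the data hold no direct example of this swap. A smaller move upwards is therefore expected, a 2.5-fold higher number from compound 3 to compound 4 (0.41 log units; beyond the scatter). For compound 4 the estimated value is 28 mg/kg, with an expected range from 7 mg/kg to 100 mg/kg.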

Compound 4, dose for half-maximal effect: 100 mg/kg
For compound 4 the middle estimate is 3.6-fold (0.55 log units) below the measured one; the measured number falls inside the stated range.
By their numbers in this assay, from the lowest: compound 2; then compound 3; then compounds 1 and 4 (each within the scatter of the next).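

Putting (pyridin-2-yl)amino in place of dipropylamino on the carbonyl carbon in this assay gives a 9.1-fold higher number from compound 3 to compound 4 (0.96 log units; beyond the scatter) even though the two groups hold the same count of heavy atoms, so size alone does not set the number at this position. With an 11-fold lower number from compound 1 to compound 2 (1.03 log units; beyond the scatter) read alongside it, both one-place steps shown put the higher number on the compound that has the amide hydrogen, across two different substituted cores. No measurement at hand explains this change.

The compounds shown cannot tell whether the amide hydrogen or the aromatic ring matters more, since both enter together in compound 4. A phenylamino group or a methyl(pyridin-2-yl)amino group on the same carbonyl carbon would pull these two apart.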